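Ethynyl addition on the fluorinated core of compound 3

The source may hold more compounds than are shown below. What is called first, only, known or untested is meant among the compounds shown, and "the series" means these compounds.

Compound 3 `CCCn1c(Cc2cc(OC)c(OC)c(OC)c2)nc2c(N)nc(F)nc21` gives 25100 nM in a functional assay on MCF7 cells (Homo sapiens) for antiproliferative activity (a higher number here means a weaker inhibitor, a lower number a stronger inhibitor), the second highest of the three numbers recorded; compound 1 `C#CCCCn1c(Cc2cc(OC)c(OC)c(OC)c2)nc2c(N)ncnc21` gives 24000 nM, and compound 2 `CCCn1c(Cc2cc(OC)c(OC)c(OC)c2)nc2c(N)ncnc21` gives 46800 nM. Neither neighbour is separated from compound 3 by more than the scatter.

Compound 4 `C#CCCCn1c(Cc2cc(OC)c(OC)c(OC)c2)nc2c(N)nc(F)nc21` carries ethynyl in place of hydrogen on a saturated chain carbon, three bonds along the chain from an aromatic nitrogen. For the measured compounds named here, the only measured step bearing on this change is a 2.0-fold higher number from compound 1 to compound 2 (0.29 log units; within the scatter), which runs in the opposite direction and stays within the scatter. Read backwards, attaching the ethynyl group to the chain of compound 2 lowered the number to that of compound 1 by an amount that does not exceed the scatter. Going by the values given here, the fluoro group of compound 3 is present in no pair where the ethynyl group changes, so any interplay between the two is unknown.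

Compound 4 is therefore expected to show a step of a 1.8-fold lower number from compound 3 to compound 4 (0.25 log units; within the scatter), a small lowering that may not exceed the scatter. The estimate for compound 4 is 14000 nM, with a range from 6000 nM to 35000 nM.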

Compound 4, half-maximal inhibitory concentration: 11000 nM
Compound 4: the middle estimate sits 1.3-fold (0.10 log units) above what was measured, within the range that was stated.
By their numbers in this assay, from the lowest: compound 4; then compounds 1, 3 and 2 (each within the scatter of the next).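

On the fluorinated core, the pent-4-yn-1-yl chain in place of propyl gives a 2.3-fold lower number from compound 3 to compound 4 (0.36 log units; beyond the scatter), so this change now shows a step beyond the scatter, though a modest one, and it runs the same way on both cores: the same change on two cores in this assay, a 2.0-fold higher number (0.29 log units; within the scatter) from compound 1 to compound 2 and a 2.3-fold higher number (0.36 log units; beyond the scatter) from compound 4 to compound 3, 1.2-fold (0.07 log units) apart, within the scatter of two such steps. Fluoro in place of hydrogen on the aromatic carbon, now on the core carrying the pent-4-yn-1-yl chain, gives a 2.2-fold lower number from compound 1 to compound 4 (0.34 log units; beyond the scatter), and this change also holds across both cores: the same change on two cores in this assay, a 1.9-fold lower number (0.27 log units; within the scatter) from compound 2 to compound 3 and a 2.2-fold lower number (0.34 log units; beyond the scatter) from compound 1 to compound 4, 1.2-fold (0.07 log units) apart, within the scatter of two such steps. In this assay, the two changes therefore combine in these four compounds with no interplay beyond the scatter.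

The ethynyl step adds chain length and a triple bond together, so a saturated pentyl chain would be needed to tell them apart. As far as these compounds go, whether an amine or a carboxylic acid at the chain end, or chloro in place of fluoro, would keep this lowering remains open.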